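Swapping a bromophenyl for a dimethylphenyl on sulfur

The source may report more compounds than this note shows. Statements on the series, on what has been measured and on what is new or still open speak of the compounds shown alone.

Measured so far:
Compound 1 `Nc1ccccc1NC(=O)c1ccc(CSc2ccc(Br)cc2)cc1` gives 45.7% in a functional assay on A549 cells (Homo sapiens) for inhibition, read by CCK-8 assay, with a stated time of 72 h, tested at 8 uM; a lower number here means less inhibition of growth, a higher number more inhibition of growth at the concentration tested.
Compound 2 `Nc1ccccc1NC(=O)/C=C/c1ccc(CSc2ccc(F)cc2)cc1` gives 59.1% in this assay.

Compound 1 has the lowest of the two numbers; compound 2 lies higher by more than the scatter, though the two differ in several places, so no single step is shown. Compound 3 `Cc1cc(C)cc(SCc2ccc(C(=O)Nc3ccccc3N)cc2)c1` is not yet measured. It differs from compound 1 thus: 3,5-dimethylphenyl in place of 4-bromophenyl on a sulfur. Among the measured compounds shown here, no measured pair shows such a change, so the step of a number 0.7 percentage points lower from compound 1 to compound 3 (within the scatter) is expected to stay within the scatter, with no clear direction. Compound 3 is estimated at 45%, within 25% to 65%.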

Compound 3, percent growth inhibition at one concentration: 78.5%
Compound 3: middle estimate off by 33.5 percentage points, on the low side; measured number above the stated range.
By their numbers in this assay, from the lowest: compound 1; then compound 2; then compound 3.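

Among the compounds shown here, changing the group on the sulfur can move growth inhibition strongly in this assay: with the rest of the molecule unchanged, 3,5-dimethylphenyl in place of 4-bromophenyl gives a number 32.8 percentage points higher from compound 1 to compound 3 (beyond the scatter), the first single-place step. This shows that the aromatic group on the sulfur is not a passive part of the molecule in this assay. Nothing here shows what lies behind the rise.

The step removes the bromine and adds both methyl groups at once, leaving their separate contributions unresolved. As far as these compounds go, whether a phenyl ring carrying one methyl, a methoxy group or a chlorine would match compound 3 remains open.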